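The compounds below may be only part of what the source reports. "The series", "measured", "known", "first", "only" and "open" are said of these compounds alone.

Series notes. Compound 3 `O=C(N[C@H]1CNC1=O)OCc1ccc(-c2ccccc2)cc1` carries a phenyl on the benzylic ring of the shared core; in an assay on HEK293 cells for inhibition of N-acylethanolamine-hydrolyzing acid amidase (Homo sapiens), read by fluorescence, with stated times of 10 min and 50 min (on this read-out higher numbers stand for weaker inhibition and lower numbers for stronger inhibition), compound 3 gives 513 nM, the lowest number among the three measured compounds. Compound 1 `O=C(N[C@H]1CNC1=O)OCc1ccc(C2CCOCC2)cc1` gives 1370 nM in this assay, and compound 2 `O=C(N[C@H]1CNC1=O)OCc1ccc(-c2cocn2)cc1` gives 1880 nM. The two measured steps that end at the phenyl both run the same way: a 2.7-fold lower number from compound 1 to compound 3 (0.43 log units; beyond the scatter) and a 3.7-fold lower number from compound 2 to compound 3 (0.56 log units; beyond the scatter). So far, then, the phenyl has given lower numbers than either the oxan-4-yl or the 1,3-oxazol-4-yl at this position, each by a modest margin.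

Compound 4 `CCc1ccc(COC(=O)N[C@H]2CNC2=O)cc1` takes the step (ethyl in place of phenyl on an aromatic carbon). Within the data shown here, no measured step removes the ring altogether; the nearest comparisons are the two ring-for-ring swaps above, both modest and both favouring the phenyl. For compound 4 a modest rise in the number in this assay is therefore expected, a 2.5-fold higher number from compound 3 to compound 4 (0.40 log units; beyond the scatter), though the lack of any direct precedent leaves the range wide. The estimate for compound 4 is 1300 nM, with a range from 500 nM to 3500 nM.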

Compound 4, half-maximal inhibitory concentration: 160 nM
Compound 4: middle estimate off by 8.1-fold (0.91 log units), on the high side; measured number outside the range, below it.
By their numbers in this assay, from the lowest: compound 4; then compound 3; then compounds 1 and 2 (each within the scatter of the next).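

In this assay, a ring is not needed at this position: the ethyl, with no ring, gives a lower number than all three ring groups on the aromatic carbon (a 3.2-fold lower number from compound 3 to compound 4 (0.51 log units; beyond the scatter); an 8.6-fold lower number from compound 1 to compound 4 (0.93 log units; beyond the scatter); a 12-fold lower number from compound 2 to compound 4 (1.07 log units; beyond the scatter)). The phenyl therefore leads only among the ring groups, and the steps to the ethyl range from modest to large, with the largest starting from the 1,3-oxazol-4-yl. No measurement shown bears on the cause of this order. 

As far as these compounds go, whether the numbers keep falling with a hydrogen or methyl in place of the ethyl, or rise again with a longer chain such as propyl or butyl, stays open. An amine or a carboxylic acid at this position is also untested among the compounds shown, so the reach of the trend beyond these four compounds remains unknown.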